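From 4-nitrophenyl to 3-hydroxyphenyl on a triple-bonded carbon

The compounds below may be only part of what the source reports. "The series", "measured", "known", "first", "only" and "open" are said of these compounds alone.

In a functional assay on NIH3T3 cells (Mus musculus) (a higher number here means that more compound is needed for the effect, a lower number that less compound is needed), compound 1 (`Cn1cncc1C(OCc1ccc(C#N)cc1-c1ccccc1)c1ccc(C#N)cc1`) gives 140 nM and compound 2 (`Cn1cncc1C(OCc1ccc(C#N)cc1C#Cc1ccc(C#N)cc1)c1ccc(C#N)cc1`) gives 11.6 nM while compound 3 (`Cn1cncc1C(OCc1ccc(C#N)cc1C#Cc1ccc([N+](=O)[O-])cc1)c1ccc(C#N)cc1`) gives 36 nM and so stands between the other two. Compound 4 (`Cn1cncc1C(OCc1ccc(C#N)cc1C#Cc1cccc(O)c1)c1ccc(C#N)cc1`) carries one change from compound 3, namely 3-hydroxyphenyl in place of 4-nitrophenyl on a triple-bonded carbon. The closest evidence is the swap of nitro for cyano, which gave a 3.1-fold higher number from compound 2 to compound 3 (0.49 log units; beyond the scatter). The ethynyl groups themselves gave a 12-fold lower number from compound 1 to compound 2 (1.08 log units; beyond the scatter) and a 3.9-fold lower number from compound 1 to compound 3 (0.59 log units; beyond the scatter) when they replaced phenyl, and compound 4 keeps the triple bond. Going by the values given here, no measured compound carries a hydroxyl group, so the direction of the step remains open. In this assay the estimated change is a 1.2-fold lower number from compound 3 to compound 4 (0.08 log units; within the scatter) and no step beyond the scatter is expected. Compound 4 is expected to give about 30 nM with an estimated range from 10 nM to 90 nM as its likely span.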

Compound 4, half-maximal effective concentration: > 0.1 nM
Compound 4 was reported as a limit; the forecaster's own chance of this, stated with the estimate: 2%; the middle value is on the limit's open side.
By their numbers in this assay, from the lowest: compound 2; then compound 3; then compound 1.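

In this assay compound 4 is reported only as the limit > 0.1 nM and so its steps from compound 1, compound 2 and compound 3 cannot be read. The compounds shown leave open where compound 4 stands relative to those three, and what 3-hydroxyphenyl in place of 4-nitrophenyl does to the number.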